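A few compounds are considered here, and "the series" means these few. Any claim that something is new, unique, unknown or untested is made for them only; others in the source may bear on it.

In a functional assay on HeLa cells (Homo sapiens) for inhibition, read by CCK-8 assay, with a stated time of 48 h (on this read-out higher numbers stand for weaker inhibition and lower numbers for stronger inhibition), compound 2 `COc1ccc(Oc2ccc(C(C)C)cc2-c2ccsc2S(=O)(=O)NCCNC(=O)Nc2cc(Cl)cc(Cl)c2)cc1OC` gives 11600 nM. Compound 1 `COc1ccc(Oc2ccc(C(C)C)cc2-c2ccsc2S(=O)(=O)NCCNC(=S)Nc2ccc([N+](=O)[O-])cc2)cc1OC` differs from compound 2 by one exchange, (a group of 12 heavy atoms (7 carbon, 2 nitrogen, 2 oxygen, 1 sulfur; one six-membered aromatic ring of carbon only) in place of a group of 11 heavy atoms (7 carbon, 1 nitrogen, 1 oxygen, 2 chlorine; one six-membered aromatic ring of carbon only), on an amine nitrogen), and in this assay compound 1 gives 11900 nM, so the exchange produced a 1.0-fold higher number from compound 2 to compound 1 (0.01 log units; within the scatter). Compound 3 `O=C(NCCNS(=O)(=O)c1ccc(-c2ccccc2O[C@H]2CC[C@H](O)CC2)s1)Nc1cc(Cl)cc(Cl)c1` is built on another core, and the difference between the two cores is not broken down here. For compound 3 this assay reports only a limit, > 20000 nM, a value at the limit of > 20000 nM in this assay, at which 1 of the 3 values shown sits. Compound 4 `O=[N+]([O-])c1ccc(NC(=S)NCCNS(=O)(=O)c2ccc(-c3ccccc3O[C@H]3CC[C@H](O)CC3)s2)cc1` carries the same change on the core of compound 3: a group of 12 heavy atoms (7 carbon, 2 nitrogen, 2 oxygen, 1 sulfur; one six-membered aromatic ring of carbon only) in place of a group of 11 heavy atoms (7 carbon, 1 nitrogen, 1 oxygen, 2 chlorine; one six-membered aromatic ring of carbon only), on an amine nitrogen. Because this change gave a 1.0-fold higher number from compound 2 to compound 1 (0.01 log units; within the scatter), a step within the scatter, the expected step from compound 3 to compound 4 is a step that the limit leaves unreadable from compound 3 to compound 4. Compound 4 is therefore estimated at about 25000 nM, expected somewhere between 10000 nM and 60000 nM, most likely again reported only as a limit.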

Compound 4, half-maximal inhibitory concentration: 5400 nM
The estimate for compound 4 lay 4.6-fold (0.67 log units) above the measured number; measured number below the stated range.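

In this assay the exchange gives an at least 3.7-fold lower number from compound 3 to compound 4 (0.56 log units; beyond the scatter), and a lower number here means stronger inhibition. The same exchange therefore did not behave alike on the two cores, so its effect on one core cannot simply be carried over to the other: the same change on two cores in this assay, a 1.0-fold higher number (0.01 log units; within the scatter) from compound 2 to compound 1 and an at least 3.7-fold lower number (0.56 log units; beyond the scatter) from compound 3 to compound 4, at least 3.7-fold (0.57 log units) apart, beyond the scatter of two such steps. The size of the newer step remains unknown, and two cores cannot explain the difference, since the starting compound 3 has only a limit: the limit of > 20000 nM in this assay, at which 1 of the 4 values shown sits.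

From the compounds shown here alone, the exchange alters two things at once, the oxygen of the urea becoming sulfur and the two chlorines giving way to a nitro group, so it remains open which of them matters. A thiourea carrying the 3,5-dichlorophenyl group on each core would help to separate them.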